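The source may report more compounds than this note shows. Statements on the series, on what has been measured and on what is new or still open speak of the compounds shown alone.

Measured compounds in the series:

compound 1 `O=C(O)CC1CCCC1Cc1ccc(OCc2ccc3ccccc3n2)cc1`: 90 nM
compound 2 `c1ccc2nc(COc3ccc(OCCCc4nnn[nH]4)cc3)ccc2c1`: 250 nM
compound 3 `O=C(O)CCCOc1ccc(OCc2ccc3ccccc3n2)cc1`: 800 nM

All three were run in a functional assay (lung) for inhibition, with Cavia porcellus as the target; a higher number here means a weaker inhibitor, a lower number a stronger inhibitor. Compound 1 gives the lowest number of the three, and both its gaps to the others are beyond the scatter, so it is the strongest inhibitor of the measured set. Compound 3 and compound 1 share the quinoline-methoxy-phenyl portion, but the rest of the two molecules differs in more than one place; that difference between the two cores is not broken down here.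

Within the data shown here, the one paired step in hand is 1H-tetrazol-5-yl in place of carboxy on a saturated chain carbon, three bonds along the chain from an oxygen on an aromatic ring. It produced a 3.2-fold lower number from compound 3 to compound 2 (0.51 log units; beyond the scatter), a gain that is modest but clearly real.

Compound 4 `c1ccc2nc(COc3ccc(CC4CCCC4Cc4nnn[nH]4)cc3)ccc2c1` is not yet measured. It differs from compound 1 by 1H-tetrazol-5-yl in place of carboxy on a saturated chain carbon bound to a saturated ring carbon. Among the measured compounds shown here, this is the same kind of change as the one from compound 3 to compound 2, but not at the same place: there the group sits on a saturated chain carbon, three bonds along the chain from an oxygen on an aromatic ring, whereas here it sits on a saturated chain carbon bound to a saturated ring carbon. Because the change from compound 3 to compound 2 gave a 3.2-fold lower number from compound 3 to compound 2 (0.51 log units; beyond the scatter), a step of similar direction and roughly similar size is expected here, with some allowance for the different surroundings: the estimated step is a 2.6-fold lower number from compound 1 to compound 4 (0.41 log units; beyond the scatter). Compound 4 is thus expected to give about 35 nM in this assay, plausibly between 12 nM and 110 nM.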

Compound 4, half-maximal inhibitory concentration: 20 nM
Estimate against measurement, compound 4: 1.8-fold (0.24 log units) above; the range from low to high includes it.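

In this assay, carboxymethyl gives way to (1H-tetrazol-5-yl)methyl on the core of compound 1, with the group on a saturated chain carbon bound to a saturated ring carbon, and the result is a 4.5-fold lower number from compound 1 to compound 4 (0.65 log units; beyond the scatter). Set beside the earlier pair, the change lowers the number on both cores, and the two steps cannot be told apart in size: the same change on two cores in this assay, a 3.2-fold lower number (0.51 log units; beyond the scatter) from compound 3 to compound 2 and a 4.5-fold lower number (0.65 log units; beyond the scatter) from compound 1 to compound 4, 1.4-fold (0.15 log units) apart, within the scatter of two such steps

This supports carrying the swap from carboxy to 1H-tetrazol-5-yl between these two cores in this assay, but it rests on two pairs only, so it shows neither that the step would hold on a further core or in a different assay, nor why the number falls.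

Still open, going by these compounds, is whether another group in place of carboxy, such as a sulfonamide or a primary amide, would lower the number as 1H-tetrazol-5-yl does, and whether a longer chain carrying the 1H-tetrazol-5-yl on the core of compound 4 would keep the gain. Also open, on these data alone, is what a fluorine or a methoxy group on the aromatic portion shared by all four compounds would do to the number in this assay.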